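This account rests on a few compounds, and the source may have more. Where it says the series, first, only, none or still open, it means among the compounds named here.

Compound 1 `COc1c(C(/C=C(\C)N2CCCC2)=C2C(=O)c3ccccc3C2=O)c(O)cc2occc12` and compound 2 `COc1c(C(/C=C(\C)N2CCCC2)=C2C(=O)c3ccccc3C2=O)c(O)c(OC)c2occc12` share one core. In a functional assay on MCF7 cells (Homo sapiens) for antiproliferative activity (on this read-out higher numbers stand for weaker inhibition and lower numbers for stronger inhibition), compound 1 gives 15.5 ug/mL, and compound 2 gives 13.2 ug/mL. The change between them is methoxy in place of hydrogen on an aromatic carbon and the step it made is a 1.2-fold lower number from compound 1 to compound 2 (0.07 log units; within the scatter). Compound 3 `COc1c2c(cc3occc13)OC1(CCCCC1)c1[se]nnc1-2` is built on a different core; the difference between the two cores is not broken down here. In this assay compound 3 gives 16.5 ug/mL, and the three measured numbers fall within the scatter of one another. Compound 4 `COc1c2c(c(OC)c3occc13)OC1(CCCCC1)c1[se]nnc1-2`, not yet measured, differs from compound 3 by methoxy in place of hydrogen on an aromatic carbon. This is the same kind of change as from compound 1 to compound 2, not the same: in compound 2 the place is part of a fused or bridged system of two rings, ortho to a fused ring, ortho to a hydroxy group, meta to a fused ring and meta to a large group, whereas in compound 4 it is part of a fused or bridged system of five rings, ortho to two fused rings and meta to two fused rings; both are para to a methoxy group. Within the data shown here, only one measured instance of the change exists. Among the measured compounds shown here, the step from compound 3 to compound 4 is expected to be a 1.2-fold lower number from compound 3 to compound 4 (0.07 log units; within the scatter), resting on the single step of a 1.2-fold lower number from compound 1 to compound 2 (0.07 log units; within the scatter), which stayed within the scatter. Compound 4 is therefore estimated at 14 ug/mL in this assay, with the expected range 8 ug/mL to 28 ug/mL.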

Compound 4, half-maximal inhibitory concentration: 15 ug/mL
Compound 4: middle estimate off by 1.1-fold (0.03 log units), on the low side, and the stated range covers the measured number.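

In this assay, methoxy in place of hydrogen on an aromatic carbon gives a 1.1-fold lower number from compound 3 to compound 4 (0.04 log units; within the scatter), and set beside the step on the other core, the two agree: the same change on two cores in this assay, a 1.2-fold lower number (0.07 log units; within the scatter) from compound 1 to compound 2 and a 1.1-fold lower number (0.04 log units; within the scatter) from compound 3 to compound 4, 1.1-fold (0.03 log units) apart, within the scatter of two such steps

On both cores the change therefore leaves the number within the scatter, so for this pair of cores the earlier step was a fair guide to the later one. This does not show that a measurable effect carries from one core to the other, since neither step is distinguishable from repeat-measurement noise, and two such steps say nothing about a third core or about a different place on the ring.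

On these data alone, whether another group on this aromatic carbon, such as an ethoxy chain, an amine or a carboxylic acid, would produce a step beyond the scatter on either core remains open. Also open, as far as these compounds go, are how the methoxy change behaves in any read-out other than this assay and what the parts that distinguish the two cores contribute.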